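The source may report more compounds than this note shows. Statements on the series, on what has been measured and on what is new or still open speak of the compounds shown alone.

Values from a functional assay on KB cells (nasopharynx, Homo sapiens) for antiproliferative activity (on this read-out higher numbers stand for weaker inhibition and lower numbers for stronger inhibition), are these:

Compound 1 `N#Cc1ccc(S(=O)(=O)Nc2cccc3c(C#N)c[nH]c23)cc1` gives 33 ug/mL
Compound 2 `COc1ccc(S(=O)(=O)Nc2cccc3c(Cl)c[nH]c23)cc1` gives 0.55 ug/mL

Of the two, compound 2 has the lower number and so the stronger inhibition, and its gap to compound 1 lies well beyond the usual scatter. Compound 3 `N#Cc1ccc(S(=O)(=O)Nc2cccc3c(Cl)c[nH]c23)cc1` has not yet been measured. It carries cyano in place of methoxy on an aromatic carbon, para to a large group (cyano in place of methoxy on an aromatic carbon), and the rest of compound 2 stays as it is.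

For the measured compounds named here, no two measured compounds differ by this one change alone, so the data give no direct guide to its size. Going by the values given here, the only hint comes from compound 1, which also carries cyano and gives 33 ug/mL in this assay as its number. A moderate rise in the number, meaning somewhat weaker inhibition, is therefore expected, though much less than the gap between the two measured compounds. The estimated change is a 2.7-fold higher number from compound 2 to compound 3 (0.44 log units; beyond the scatter) in this assay and remains uncertain. The expected value for compound 3 is 1.5 ug/mL with an estimated range from 0.3 ug/mL to 7 ug/mL in this measurement.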

Compound 3, half-maximal inhibitory concentration: 11 ug/mL
Beside the measured number, compound 3's estimate is 7.3-fold (0.87 log units) below it, and the stated range ends below it.
By their numbers in this assay, from the lowest: compound 2; then compound 3; then compound 1.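

In this assay, for the compounds shown here, cyano in place of methoxy on an aromatic carbon para to a large group gives a 20-fold higher number from compound 2 to compound 3 (1.30 log units; beyond the scatter) and is the first direct reading of this change, which shows that the group held at this position matters greatly. Methoxy and cyano have the same counts of heavy atoms and hydrogen-bond acceptors, so these counts do not separate compound 2 from compound 3, although their numbers lie far apart. Chloro in place of cyano on an aromatic carbon elsewhere in the molecule gives a 3.0-fold lower number from compound 1 to compound 3 (0.48 log units; beyond the scatter) and is a modest step, so of the two single changes now readable, the one at the methoxy position is the larger. Nothing measured here explains why the methoxy and cyano compounds differ so much.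

On these data alone, it remains open whether a hydroxyl group, an amine or a longer chain such as ethoxy at this position would give a number closer to that of compound 2 or to that of compound 3. As far as these compounds go, the size of the methoxy-to-cyano step in the setting of compound 1 also remains open.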